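This account rests on a few compounds, and the source may have more. Where it says the series, first, only, none or still open, it means among the compounds named here.

Measured compounds:
compound 1 `COc1ccc2nc(C)cc(OCC(=O)Nc3cc(C)cc(C)c3)c2c1` — in a physicochemical assay for solubility, in phosphate buffer, measured as kinetic solubility, with a stated time of 1 h, at pH 7.4 (on this read-out lower numbers stand for lower solubility and higher numbers for higher solubility), compound 1 gives 26000 nM.
compound 2 `Cc1cc(C)cc(NC(=O)COc2cc(C)nc3ccc(OCc4ccccc4)cc23)c1` — in this assay compound 2 gives < 1000 nM, which is a limit of the assay and not a number.

Among the compounds with values here, compound 1 carries the only number recorded in this assay; the other value is a limit (the limit of < 1000 nM in this assay, at which 1 of the 2 values shown sits). Within the data shown here, the one measured step, an at least 26-fold lower number from compound 1 to compound 2 (1.41 log units; beyond the scatter), is large. Compound 3 `COc1ccc2nc(C)cc(OCC(=O)Nc3cccc(C)c3)c2c1` is not yet measured. It differs from compound 1 by hydrogen in place of methyl on an aromatic carbon; cut one bond further out, 3,5-dimethylphenyl becomes 3-methylphenyl. Among the measured compounds shown here, no measured step touches this part of the molecule, so the step from compound 1 to compound 2 gives no direct guide, and no step beyond the scatter is expected in this assay in either direction. Compound 3 is therefore estimated at 30000 nM, within 13000 nM to 70000 nM, an expected step of a 1.2-fold higher number from compound 1 to compound 3 (0.06 log units; within the scatter).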

Compound 3, solubility: 193000 nM
For compound 3 the middle estimate is 6.4-fold (0.81 log units) below the measured one; the measured number lies above the stated range.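

In this assay, hydrogen in place of methyl on this aromatic carbon gives a 7.4-fold higher number from compound 1 to compound 3 (0.87 log units; beyond the scatter). Within the data shown here, the 3,5-dimethylphenyl group, which no earlier step touched, is therefore not a silent part of the series: a change of a single heavy atom there moves the read-out beyond the scatter. Nothing recorded for this series accounts for the size or direction of this step.

Only methyl and hydrogen are shown at this aromatic carbon, so an amine or a carboxylic acid in the same place would show whether the step is tied to the loss of methyl or to any change there. Also open, from the compounds shown here alone, is a plain phenyl with neither methyl group, and whether the same change would hold on the core of compound 2.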